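The compounds below may be only part of what the source reports. "The series", "measured", "known", "first", "only" and "open" are said of these compounds alone.

In a functional assay on NCI-H520 cells (Homo sapiens) (on this read-out higher numbers stand for weaker inhibition of growth and lower numbers for stronger inhibition of growth), compound 1 `O=S(=O)(/C=C/c1ccc(F)cc1)Cc1ccc(Nc2ncnc3ccccc23)cc1` gives 13000 nM and compound 3 `O=S(=O)(/C=C/c1ccc(Cl)cc1)Cc1ccc(Nc2ncnc3ccccc23)cc1` gives 46000 nM on the same core. Compound 2 `O=S(=O)(/C=C/c1ccc(Br)cc1)Cc1ccc(Nc2ncnc3ccccc23)cc1` gives > 100000 nM as a limit of the assay, not a number. Compound 3 therefore holds the higher of the two true numbers, and chloro in place of fluoro gave a 3.5-fold higher number from compound 1 to compound 3 (0.55 log units; beyond the scatter) in that comparison. Compound 4 `O=S(=O)(/C=C/c1ccc(Cl)cc1Cl)Cc1ccc(Nc2ncnc3ccccc23)cc1` has chloro in place of hydrogen on an aromatic carbon, ortho to a large group and meta to a chloro group, with chloro in place of hydrogen on an aromatic carbon as the count. Among the measured compounds shown here, no measured step adds a group. The closest guides are that chloro step and an at least 7.6-fold higher number from compound 1 to compound 2 (0.88 log units; beyond the scatter) for bromo in place of fluoro, and both raised the number. A small rise in this assay is therefore expected, an estimated 1.5-fold higher number from compound 3 to compound 4 (0.18 log units; within the scatter) that may stay within the usual scatter. Compound 4 is expected near 70000 nM within an estimated range from 25000 nM to 100000 nM in this assay.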

Compound 4, concentration for 50% growth inhibition: 12000 nM
For compound 4 the middle estimate is 5.8-fold (0.77 log units) above the measured one; measured number outside the range, below it.
By their numbers in this assay, from the lowest: compounds 4 and 1 (each within the scatter of the next); then compound 3. At a limit, above all of these: compound 2.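

In this assay, a second chloro group, ortho to a large group, gave a 3.8-fold lower number from compound 3 to compound 4 (0.58 log units; beyond the scatter), whereas replacing fluoro at the one ring position varied earlier raised the number. The 2,4-dichlorophenyl group also gave a 1.1-fold lower number from compound 1 to compound 4 (0.03 log units; within the scatter), so it offers no gain over the 4-fluorophenyl group. The other step, an at least 8.3-fold lower number from compound 2 to compound 4 (0.92 log units; beyond the scatter), is only a minimum: the limit of > 100000 nM in this assay, at which 1 of the 4 values shown sits.

Still open, going by these compounds, is whether a methoxy group or an amine at this same position would also lower the number. On these data alone, it is equally open whether adding a second fluoro group to compound 1 would do so.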